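Capping a phenol on a triazole-bearing core

The source may report more compounds than this note shows. Statements on the series, on what has been measured and on what is new or still open speak of the compounds shown alone.

Compound 1 `Cc1c(O)ccc2c1[C@H](Cn1cc(-c3ccc(F)cc3)nn1)[C@@]13CC(=O)[C@@](C)(CC[C@@H]21)C3` carries a free hydroxy group on its aromatic ring and a fluoro-substituted aryl ring on the triazole. In a functional assay on SMMC-7721 cells (Homo sapiens) for cytotoxicity, read by MTT assay, with a stated time of 4 days (on this read-out higher numbers stand for weaker inhibition and lower numbers for stronger inhibition), compound 1 gives > 20000 nM, which is a limit of the assay rather than a number. Compound 2 `Cc1c(O)ccc2c1[C@H](Cn1cc(-c3ccc(C(F)(F)F)cc3)nn1)[C@@]13CC(=O)[C@@](C)(CC[C@@H]21)C3` changes only the aryl substituent; in this assay compound 2 gives > 20000 nM, again a limit. Compound 3 `Cc1ccc(-c2cn(C[C@H]3c4c(ccc(O)c4C)[C@@H]4CC[C@@]5(C)C[C@]43CC5=O)nn2)cc1` puts a methyl group in that place; in this assay compound 3 gives > 20000 nM, also a limit. The steps a step that the two limits leave unreadable from compound 1 to compound 2, a step that the two limits leave unreadable from compound 1 to compound 3 and a step that the two limits leave unreadable from compound 2 to compound 3 therefore cannot be sized, because every value sits at the limit of > 20000 nM in this assay, at which 3 of the 3 values shown sit.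

Compound 4 `Cc1ccc(S(=O)(=O)Oc2ccc3c(c2C)[C@H](Cn2cc(-c4ccc(F)cc4)nn2)[C@@]24CC(=O)[C@@](C)(CC[C@@H]32)C4)cc1` is not yet measured. It differs from compound 1 by (4-methylphenyl)sulfonyl in place of hydrogen on an oxygen on an aromatic ring. Among the measured compounds shown here, none of the measured steps touches this oxygen; each of them alters only the aryl ring on the triazole, and each left the limit in place, so they give no direct guide to the size or direction of the new step. The expectation is that compound 4 stays near the limit, meaning a step that the limit leaves unreadable from compound 1 to compound 4 that is expected to be none beyond the scatter. Compound 4 is therefore estimated at 25000 nM in this assay, within a range from 6000 nM to 100000 nM, with a strong chance that only a limit is reported again.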

Compound 4, half-maximal inhibitory concentration: > 20000 nM
Compound 4 ended at the assay's limit; the forecaster's own chance of this, stated with the estimate: 75%; the middle value is on the limit's open side.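

In this assay compound 4 gives > 20000 nM as a limit of the assay, not a number. The step from compound 1 to compound 4 cannot be read, nor can any other step among compounds 1 to 4, because all their values sit at one limit: (the limit of > 20000 nM in this assay, at which 4 of the 4 values shown sit). The compounds shown leave open which change to the shared core, if any, would give a readable value in this assay at all.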